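The compounds below may be only part of what the source reports. "The series", "measured", "known", "first", "only" and "open" are said of these compounds alone.

Three compounds have been measured in a functional assay on U-87MG ATCC cells for cytotoxicity against U-87 MG (Homo sapiens), read by colorimetric assay and MTT assay; on this read-out higher numbers stand for weaker inhibition and lower numbers for stronger inhibition:

compound 1, `COc1ccc(-c2cc3c(OC)cc(OC)cc3n(C)c2=O)cc1`, gives 10000 nM;
compound 2, `COc1ccc(-c2cc3c(OC)cc(OC)cc3n(CC#N)c2=O)cc1`, gives 10000 nM;
compound 3, `COC(=O)CCn1c(=O)c(-c2ccc(OC)cc2)cc2c(OC)cc(OC)cc21`, gives 10000 nM.

On these numbers compound 1 stands level with compounds 2 and 3. The step of no change at the digits printed from compound 1 to compound 2 (within the scatter) and the step of no change at the digits printed from compound 1 to compound 3 (within the scatter) both stay within the scatter, as does no change at the digits printed from compound 2 to compound 3 (within the scatter). All three of those steps alter only the group on a saturated chain carbon bound to an aromatic nitrogen.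

Compound 4, `COc1cc(OC)c2cc(-c3ccc(OC(C)=O)cc3)c(=O)n(C)c2c1`, differs from compound 1 elsewhere: acetyl in place of methyl on an oxygen on an aromatic ring. Among the compounds with values here, no measured step touches an oxygen on an aromatic ring whose other neighbours are aromatic carbon, so no step bears on this change directly. What the measured set shows is that the changes tried so far around the shared core left the read-out flat. Compound 4 is therefore expected to sit at about the same level, with the step of no change at the digits printed from compound 1 to compound 4 (within the scatter) expected to fall within the scatter. The estimated value of compound 4 in this assay is 10000 nM, with a range from 5000 nM to 20000 nM.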

Compound 4, half-maximal inhibitory concentration: 10000 nM
For compound 4 middle estimate and measured number coincide at the digits printed, within the range that was stated.
By their numbers in this assay, from the lowest: compounds 1, 2, 3 and 4 (each within the scatter of the next).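

Compound 4 moves the change away from the group on the saturated chain carbon bound to an aromatic nitrogen, to an oxygen on an aromatic ring. In this assay, acetyl in place of methyl at that oxygen gives no change at the digits printed from compound 1 to compound 4 (within the scatter). The flat read-out seen among compounds 1, 2 and 3 therefore now holds at a second place on the shared core, though nothing available here accounts for it.

Going by these compounds, compound 4 gives 10000 nM, and whether a free hydroxyl, an amine or a longer acyl chain such as butanoyl on this oxygen would shift that read-out remains open. Also open, on these data alone, is whether any change to the shared core can move the value in this assay at all.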